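Compound 3 to compound 4: trifluoromethyl for methyl

This account rests on a few compounds, and the source may have more. Where it says the series, first, only, none or still open, it means among the compounds named here.

Values in a functional assay on HL-60 cells (Homo sapiens) for inhibition, read by MTT assay, with a stated time of 72 h; on this read-out higher numbers stand for weaker inhibition and lower numbers for stronger inhibition:
- compound 1 `COc1cccc(N2CCN(C(=O)c3oc(C(F)(F)F)nc3-c3cccc(F)c3)CC2)c1`: "not active" (no number reported)
- compound 2 `Cc1ccc(C)c(N2CCN(C(=O)c3oc(C)nc3-c3ccc(F)cc3)CC2)c1`: 358 nM
- compound 3 `COc1cccc(N2CCN(C(=O)c3oc(C)nc3-c3ccc(F)cc3)CC2)c1`: 112 nM

Compound 3 gives 112 nM, the lower of the two numbers available. Going by the values given here, the one measured step is a 3.2-fold lower number from compound 2 to compound 3 (0.50 log units; beyond the scatter). Compound 1 gives no number, only the reading "not active" (no number reported).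

Next in line is compound 4 `COc1cccc(N2CCN(C(=O)c3oc(C(F)(F)F)nc3-c3ccc(F)cc3)CC2)c1`, with trifluoromethyl in place of methyl on an aromatic carbon of the five-membered aromatic ring: trifluoromethyl in place of methyl on an aromatic carbon. Among the compounds with values here, no measured pair isolates this swap. The step of a 3.2-fold lower number from compound 2 to compound 3 (0.50 log units; beyond the scatter) concerns the group on the amine nitrogen in a ring, not this place, and offers only a rough scale for the series, with no direction. The sole hint on direction is compound 1, which also carries trifluoromethyl on the core and reads "not active" (no number reported). That hint is limited, as compound 1 also differs from compound 4 in its fluorophenyl group. Within the data shown here, a move towards a higher number in this assay is therefore expected, larger than the one measured step, and a reading without a number remains possible. The expected step is a 7.1-fold higher number from compound 3 to compound 4 (0.85 log units; beyond the scatter). For compound 4 the estimated value is 800 nM, with an expected range of 200 nM to 5000 nM.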

Compound 4, half-maximal inhibitory concentration: "not active" (no number reported)
Compound 4: no number reported, so the estimate cannot be set against anything.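

In this assay compound 4 gives "not active" (no number reported) and so yields no readable step from compound 3. No supporting data bear on this result. The compounds shown leave open the size of any change with trifluoromethyl in place of methyl, and whether any trifluoromethyl compound in this series gives a number.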